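This account rests on a few compounds, and the source may have more. Where it says the series, first, only, none or still open, it means among the compounds named here.

Series notes. Among the measured compounds shown here, compound 1 `O=C(NO)[C@H]1CC2(CC2)CN[C@@H]1C(=O)N1CCN(c2cccc(Cl)c2)CC1` carries the lowest number of the three measured so far; in an assay on isolated protein for binding affinity to disintegrin and metalloproteinase domain-containing protein 10 (Homo sapiens) (on this read-out higher numbers stand for weaker inhibition and lower numbers for stronger inhibition), compound 1 gives 14 nM. Compound 2 `Cc1cccc(C2=CCN(C(=O)[C@H]3NCC4(CC4)C[C@@H]3C(=O)NO)CC2)c1` gives 25 nM and compound 3 `COC(=O)N1CC2(CC2)C[C@H](C(=O)NO)[C@H]1C(=O)N1CC=C(c2ccccc2)C1` gives 26 nM in this assay; both gaps to compound 1 lie within the scatter, so no order among the three can be read from these numbers. Compound 4 `Cc1cc(N2CCN(C(=O)[C@H]3NCC4(CC4)C[C@@H]3C(=O)NO)CC2)ccc1C#N` is not yet measured. It differs from compound 1 in one place: 4-cyano-3-methylphenyl in place of 3-chlorophenyl on an amine nitrogen in a ring. For the measured compounds named here, no measured pair shows how this change moves the number, so only a small step, a 1.3-fold higher number from compound 1 to compound 4 (0.11 log units; within the scatter), is expected, in no direction beyond the scatter. Compound 4 is therefore estimated at 18 nM in this assay, with a range from 7 nM to 45 nM.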

Compound 4, half-maximal inhibitory concentration: 38 nM
Estimate against measurement, compound 4: 2.1-fold (0.32 log units) below; measured number inside the range.
By their numbers in this assay, from the lowest: compounds 1, 2, 3 and 4 (each within the scatter of the next, the first and the last beyond it).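

Among the compounds shown here, on the amine nitrogen of the six-membered non-aromatic ring with 2 nitrogen, 4-cyano-3-methylphenyl in place of 3-chlorophenyl gives a 2.7-fold higher number from compound 1 to compound 4 (0.43 log units; beyond the scatter) in this assay, the only step read so far and a modest one. This position therefore responds to the substituents on the aromatic ring, even though that six-membered aromatic ring of carbon only is kept. No measured evidence accounts for the step. On these data alone, whether the nitrile, the methyl or the loss of chlorine carries it stays open. Also open, as far as these compounds go, is how a pyridine ring or an aminophenyl group would read here.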